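Benzyl to 3-Methylphenyl: One Swap, One Open Number

A few compounds are considered here, and "the series" means these few. Any claim that something is new, unique, unknown or untested is made for them only; others in the source may bear on it.

In a functional assay on B16 cells (Mus musculus) for cytotoxicity, read by CCK-8 assay, with a stated time of 24 h (on this read-out lower numbers stand for stronger inhibition and higher numbers for weaker inhibition), compound 2 (`COc1ccccc1Oc1c(N)nc(Cc2ccccc2)nc1OCCO`) reads 47400 nM and is the weaker of the two measured, while compound 1 (`COc1ccccc1Oc1c(N)nc(-c2cccc(C)c2)nc1Cl`) reads 13100 nM on the same test. Compound 3 (`COc1ccccc1Oc1c(N)nc(-c2cccc(C)c2)nc1OCCO`) is still unmeasured and differs from compound 2 by one swap (3-methylphenyl in place of benzyl on an aromatic carbon): 3-methylphenyl in place of benzyl on an aromatic carbon. Compound 1 (13100 nM) also carries 3-methylphenyl, which points to a lower number, though it differs in a second place too. In this assay a modest step down is expected, near the edge of the scatter, with a 2.1-fold lower number from compound 2 to compound 3 (0.31 log units; beyond the scatter) as the estimated size. The estimated value for compound 3 is 23000 nM (range 9000 nM to 60000 nM).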

Compound 3, half-maximal inhibitory concentration: 70900 nM
Estimate against measurement, compound 3: 3.1-fold (0.49 log units) below; measured number outside the range, above it.
By their numbers in this assay, from the lowest: compound 1; then compounds 2 and 3 (each within the scatter of the next).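

In this assay, 3-methylphenyl in place of benzyl on the carbon between two ring nitrogen atoms gives a 1.5-fold higher number from compound 2 to compound 3 (0.17 log units; within the scatter), so with 2-hydroxyethoxy on the ring these two groups cannot be told apart. The larger step lies at the other place: 2-hydroxyethoxy in place of chloro gives a 5.4-fold higher number from compound 1 to compound 3 (0.73 log units; beyond the scatter), so 3-methylphenyl alone does not bring the low number of compound 1 with it. Nothing here explains either step. Still open, going by these compounds, is whether benzyl would read the same with chloro on the ring, and how an amine such as morpholine or a carboxylic acid would read in place of 2-hydroxyethoxy.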